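This account rests on a few compounds, and the source may have more. Where it says the series, first, only, none or still open, it means among the compounds named here.

Compound 1 `CN(C)CCCOc1ccc(CN2CC[C@H](NC(=O)c3ccc(C#N)cc3)C2)cc1` and compound 2 `CN(C)CCCOc1ccc(CN2CC[C@H](NC(=O)c3ccc(C(F)(F)F)cc3)C2)cc1` share one core and differ in a single group. In an assay on HEK293 cells for binding affinity to Urotensin-2 receptor (Homo sapiens), read by radioligand binding (a higher number here means a weaker inhibitor, a lower number a stronger inhibitor), compound 1 gives < 10000 nM, which is a limit of the assay and not a number. In this assay compound 2 likewise gives < 10000 nM, again only a limit. The step that the two limits leave unreadable from compound 1 to compound 2 can therefore not be read, since both values sit at the limit of < 10000 nM in this assay, at which 2 of the 2 values shown sit. Compound 3 `CN(C)CCCOc1ccc(CN2CC[C@H](NC(=O)c3ccc(-c4ccccc4)cc3)C2)cc1` carries phenyl in place of trifluoromethyl on an aromatic carbon. No readable measured step bears on this change. Compound 3 is expected to give about 1500 nM in this assay, within 150 nM to 10000 nM. That estimate means an expected step that the limit leaves unreadable from compound 2 to compound 3, which the shown values cannot confirm.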

Compound 3, inhibition constant: < 10000 nM
Compound 3 was reported as a limit; the forecaster's own chance of this, stated with the estimate: 40%; the middle value is on the limit's open side.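

No step can be read among compound 1, compound 2 and compound 3, since each value is only a limit of the assay: the limit of < 10000 nM in this assay, at which 3 of the 3 values shown sit.

The compounds shown leave open how strongly each one binds in this assay, and whether cyano, trifluoromethyl or phenyl makes any difference.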